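Swapping a hydroxymethyl for an alkynyl on a deoxyuridine

A few compounds are considered here, and "the series" means these few. Any claim that something is new, unique, unknown or untested is made for them only; others in the source may bear on it.

Compound 1 `O=c1[nH]c(=O)n([C@H]2C[C@H](O)[C@@H](CO)O2)cc1CO`: 9180 nM
Compound 2 `Nc1ncnc2c1nnn2C[C@H]1CCC[C@H]1CO`: > 200000 nM

Of the compounds shown here, two have been measured in an ADME assay on L1210/0 cells (Mus musculus) for cytotoxicity, with a stated time of 48 h; a higher number here means a weaker inhibitor, a lower number a stronger inhibitor. Compound 1 `O=c1[nH]c(=O)n([C@H]2C[C@H](O)[C@@H](CO)O2)cc1CO` gives 9180 nM in this assay. For compound 2 `Nc1ncnc2c1nnn2C[C@H]1CCC[C@H]1CO` the result is only a limit of the assay, > 200000 nM, and no number. Among the measured compounds shown here, compound 1 therefore holds the only numerical value shown, with the other result sitting at the limit (the limit of > 200000 nM in this assay, at which 1 of the 2 values shown sits).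

The step of interest leads from compound 1 to compound 3 `CC(C)(C)C#Cc1cn([C@H]2C[C@H](O)[C@@H](CO)O2)c(=O)[nH]c1=O`. The change is 3,3-dimethylbut-1-yn-1-yl in place of hydroxymethyl on an aromatic carbon, a 3,3-dimethylbut-1-yn-1-yl entering where a hydroxymethyl leaves, on an aromatic carbon of the six-membered ring with two nitrogens. For the measured compounds named here, no comparable step between measured compounds is available, so there is no measured guide for its size.

Compound 3 is expected to land at about 20000 nM in this assay, within 3000 nM to 150000 nM. The step from compound 1 to compound 3 is estimated as a 2.2-fold higher number from compound 1 to compound 3 (0.34 log units; beyond the scatter), a modest loss of potency that may still fall within the usual scatter.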

Compound 3, half-maximal inhibitory concentration: > 200000 nM
Compound 3 was reported as a limit; the forecaster's own chance of this, stated with the estimate: 15%; middle value at least 10-fold (1.00 log units) away from the limit.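

In this assay compound 3 gives > 200000 nM, which is a limit of the assay and not a number. Among the compounds shown here, this gives the first measured step at this position, an at least 21-fold higher number from compound 1 to compound 3 (1.33 log units; beyond the scatter), on exchanging hydroxymethyl for 3,3-dimethylbut-1-yn-1-yl on the aromatic carbon of the six-membered aromatic ring with 2 nitrogen, and it shows that this exchange takes the core of compound 1 from a measurable value to the end of the assay's range, a large change made in one place only. With this result, most of the values now shown stand at the limit rather than as numbers: the limit of > 200000 nM in this assay, at which 2 of the 3 values shown sit.

Going by these compounds, whether a smaller group at this position, such as ethynyl or methyl, or an alkynyl chain ending in a hydroxyl would keep a measurable value remains open. The compounds shown also leave open which feature of the 3,3-dimethylbut-1-yn-1-yl group matters, the triple bond or the branched end, and a straight propynyl or hexynyl chain at the same carbon would be needed to separate the two.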